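Tetrasubstituted imidazole series: ester to amide on the alkyl chain

The source may hold more compounds than are shown below. What is called first, only, known or untested is meant among the compounds shown, and "the series" means these compounds.

Two compounds of the series carry a measured value in an assay on H4 cells for inhibition of Fatty-acid amide hydrolase 1 (Homo sapiens); on this read-out lower numbers stand for stronger inhibition and higher numbers for weaker inhibition. Compound 1 `CCOC(=O)CCCOc1cccc(-n2cnc(-c3ccccc3)c2-c2ccccc2)c1` gives 91 nM in this assay. Compound 2 `CCOC(=O)CC(C)CCCCCn1c(C)nc(-c2ccccc2)c1-c1ccccc1` gives 130 nM in this assay, the higher of the two numbers, though its distance to compound 1 lies within the usual scatter, so the two read as equivalent. Compound 3 `Cc1nc(-c2ccccc2)c(-c2ccccc2)n1CCCCCCC(=O)N(C)C` is not yet measured in this assay. It differs from compound 2 in one place: (dimethylcarbamoyl)methyl in place of 1-((ethoxycarbonyl)methyl)ethyl on a saturated chain carbon, five bonds along the chain from an aromatic nitrogen. The chain thus ends in a dimethylcarbamoyl group where compound 2 carries an ethoxycarbonyl group, and the branch methyl is gone. Among the measured compounds shown here, no pair of measured compounds shows a change of this kind, so the size of the step has no precedent; the only anchor is that compound 1 and compound 2, with different chain ends and different attachment of the chain to the core, sit within the scatter of each other. The expectation is for compound 3 to give roughly 250 nM in this assay, the range spanning 80 nM to 800 nM. That estimate means a step of a 1.9-fold higher number from compound 2 to compound 3 (0.28 log units; within the scatter), expected to be a modest weakening at most and possibly none beyond the scatter.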

Compound 3, half-maximal inhibitory concentration: 970 nM
Estimate against measurement, compound 3: 3.9-fold (0.59 log units) below; measured number above the stated range.
By their numbers in this assay, from the lowest: compounds 1 and 2 (each within the scatter of the next); then compound 3.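

Among the compounds shown here, the chain end at this place is not a neutral site in this assay: replacing 1-((ethoxycarbonyl)methyl)ethyl with (dimethylcarbamoyl)methyl on a saturated chain carbon, five bonds along the chain from an aromatic nitrogen, gives a 7.5-fold higher number from compound 2 to compound 3 (0.87 log units; beyond the scatter) and is the first step that can be read at this position. The change is a double one, since the ethoxycarbonyl end becomes a dimethylcarbamoyl end and the branch methyl goes with it, so the step belongs to the pair of changes together and not to either one alone. Nothing shown gives a reason for the size of this step.

The compounds shown leave open how the step divides between the two changes: an unbranched chain ending in ethoxycarbonyl, or a branched chain ending in dimethylcarbamoyl, would separate them. Also open, on these data alone, is how other chain ends at the same place, such as a carboxylic acid, a primary amide or a methyl ester, would read against compound 2 in this assay.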